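Swapping the ester for a cyclopropyl ketone on the shared core

The source may report more compounds than this note shows. Statements on the series, on what has been measured and on what is new or still open speak of the compounds shown alone.

Compound 2 `CC1=C(C(=O)OC(C)(C)C)C(c2ccoc2)NC(=O)N1` stands lowest of the two compounds measured in an assay on membranes from HeLa cells for displacement of a labelled ligand from adenosine receptor A3 (Homo sapiens), read by scintillation counting, with a stated time of 180 min, tested at 1 uM; a lower number here means less inhibition, a higher number more inhibition at the concentration tested (going by the name of the read-out): in that assay compound 2 gives 2%, while compound 1 `CC1=C(C(=O)OCC(C)C)C(c2ccoc2)NC(=O)N1` gives 16%. For the measured compounds named here, the single measured step, a number 14 percentage points lower from compound 1 to compound 2 (beyond the scatter), concerns only which alkyl group sits on that oxygen. Compound 3 `CC1=C(C(=O)C2CC2)C(c2ccoc2)NC(=O)N1` changes something else: cyclopropyl in place of tert-butoxy on a carbonyl carbon. Going by the values given here, no measured step covers a change of this kind, so there is nothing to predict a large movement in either direction. For compound 3 the estimate is 8%, with a range from 0% to 25%, an expected step of a number 6 percentage points higher from compound 2 to compound 3 (within the scatter) that stays within the scatter.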

Compound 3, a percentage reported as inhibition, at one concentration (the size of the read-out at that concentration, not a potency): 16%
For compound 3 the middle estimate is 8 percentage points below the measured one; the range from low to high includes it.
By their numbers in this assay, from the lowest: compound 2; then compounds 1 and 3 (each within the scatter of the next).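

Replacing tert-butoxy with cyclopropyl on the carbonyl carbon gives a number 14 percentage points higher from compound 2 to compound 3 (beyond the scatter) in this assay, whereas replacing isobutoxy with cyclopropyl gives no change at the digits printed from compound 1 to compound 3 (within the scatter). Among these three compounds, an oxygen attached to the carbonyl carbon is therefore not required to reach this level of inhibition, and only the tert-butoxy compound stands apart. Nothing available here explains the difference between these groups. On these data alone, whether an amine or a longer carbon chain on the carbonyl carbon would raise or lower the number remains open.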